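This account rests on a few compounds, and the source may have more. Where it says the series, first, only, none or still open, it means among the compounds named here.

Compound 3, `O=S(=O)(c1cc(Cl)cc(Cl)c1)c1cnc2cc(F)ccc2c1-c1ccccc1F`, gives 0.93 mL/min in an ADME assay on microsomes from liver (Homo sapiens) for metabolic stability, tested at 2.5 uM; a higher number here means faster removal of the compound, a lower number slower removal. Among the three compounds measured, compound 3 stands at the highest number, though its nearest neighbour compound 2, `O=S(=O)(c1ccc(F)c(F)c1)c1cnc2cc(F)ccc2c1-c1cccc(F)c1`, which gives 0.6 mL/min, lies within the scatter of it; only compound 1, `O=S(=O)(c1ccc(F)c(F)c1)c1cnc2cc(F)ccc2c1-c1ccc(Cl)cc1`, with 0.01 mL/min, sits clearly lower. Compound 4, `O=S(=O)(c1ccc(F)c(F)c1)c1cnc2cc(F)ccc2c1-c1ccccc1F`, is yet to be measured. It differs from compound 3 by 3,4-difluorophenyl in place of 3,5-dichlorophenyl on a sulfonyl sulfur. Among the compounds with values here, the one single-point step recorded, a 60-fold higher number from compound 1 to compound 2 (1.78 log units; beyond the scatter), concerns the aryl group attached to the core rather than the group on the sulfonyl sulfur, so it does not speak directly to this change; it only shows that single aryl swaps can move the number greatly. Compound 2 and compound 4 share the 3,4-difluorophenyl on the sulfonyl sulfur, and compound 2 shows a number within the scatter of compound 3. Compound 4 is therefore expected to give 0.7 mL/min, within 0.25 mL/min to 2 mL/min. This estimate corresponds to an expected step of a 1.3-fold lower number from compound 3 to compound 4 (0.12 log units; within the scatter), one not beyond the scatter.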

Compound 4, intrinsic clearance in a liver preparation (reported as CLH), per the amount of preparation that the assay uses: 0.79 mL/min
Compound 4: the middle estimate sits 1.1-fold (0.05 log units) below what was measured; the measured number falls inside the stated range.
By their numbers in this assay, from the lowest: compound 1; then compounds 2, 4 and 3 (each within the scatter of the next).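

Within the data shown here, on the sulfonyl sulfur, this is the first direct reading of a swap at this position: in this assay, 3,4-difluorophenyl in place of 3,5-dichlorophenyl gives a 1.2-fold lower number from compound 3 to compound 4 (0.07 log units; within the scatter), so the two groups cannot be told apart here. On the aromatic carbon, 2-fluorophenyl in place of 3-fluorophenyl gives a 1.3-fold higher number from compound 2 to compound 4 (0.12 log units; within the scatter), so moving from one fluorophenyl to the other also stays within the scatter. By contrast, 2-fluorophenyl in place of 4-chlorophenyl gives a 79-fold higher number from compound 1 to compound 4 (1.90 log units; beyond the scatter), a second large step involving compound 1, the only compound shown with 4-chlorophenyl.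

Nothing shown accounts for the size of these steps. Still open, going by these compounds, is whether a morpholine or a simple alkyl chain on the sulfonyl sulfur would give a similar number, and whether 4-chlorophenyl would keep its low number alongside 3,5-dichlorophenyl.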